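Cytotoxicity notes on a trimethoxyphenyl-substituted fused series

This account rests on a few compounds, and the source may have more. Where it says the series, first, only, none or still open, it means among the compounds named here.

Measured compounds:
- compound 1, `COc1cc(N2C(N)=C(C#N)C(c3ccc(O)cc3)C3=C2CC(C)(C)CC3=O)cc(OC)c1OC`: 75800 nM
- compound 2, `COc1cc(N2C(N)=C(C#N)C(c3c(OC)ccc4ccccc34)C3=C2CC(C)(C)CC3=O)cc(OC)c1OC`: "not active" (no number reported)
- compound 3, `COc1cc(N2C(N)=C(C#N)C(/C=C/c3ccccc3)C3=C2CC(C)(C)CC3=O)cc(OC)c1OC`: "not active" (no number reported)

In a functional assay on Ehrlich cells (Mus musculus) for cytotoxicity (a lower number here means a stronger inhibitor, a higher number a weaker inhibitor), compound 1 gives 75800 nM, a weak result on its own. Compound 2 gives "not active" (no number reported) and compound 3 gives "not active" (no number reported), both without a number in this assay, so compound 3 stands together with compound 2 as one of two entries without a value, and nothing in the set places it above or below compound 1.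

The step to compound 4, `COc1cc(N2C(N)=C(C#N)C(c3ccccc3)C3=C2CC(C)(C)CC3=O)cc(OC)c1OC`, is a single change: phenyl in place of 2-phenylethenyl on a saturated ring carbon. Going by the values given here, no measured pair covers this exact change, so the size of the step in this assay is not known from the data. Among the compounds with values here, since compound 3 has no number, the direction cannot be stated against a value; the expectation for compound 4 rests on the one number in the set, compound 1 at 75800 nM, which shares the core and carries a six-membered aromatic ring at the same saturated ring carbon.

Compound 4 is expected to be weak in this assay, with an estimate of 100000 nM and a range from 30000 nM to 400000 nM, and a fair chance that only a not-active outcome is recorded.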

Compound 4, half-maximal inhibitory concentration: "not active" (no number reported)
For compound 4 the study gives words and no number; no gap can be computed for the estimate.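

In this assay, going by these compounds alone, compound 3 gives "not active" (no number reported) and compound 4 gives "not active" (no number reported) so no step between the two can be read. The compounds shown leave open how phenyl and 2-phenylethenyl rank against each other on this saturated ring carbon. No supporting evidence bears on this result.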